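The source may hold more compounds than are shown below. What is called first, only, known or untested is meant among the compounds shown, and "the series" means these compounds.

Compound 1, `COc1nc2ccc(Br)cc2cc1C(c1ccccc1)n1cc(C2CC2)nn1`: -5.84%
Compound 2, `COc1nc2ccc(Br)cc2cc1C(c1ccccc1)n1cc(-c2ccc(Br)cc2)nn1`: 6.92%
Compound 3, `COc1nc2ccc(Br)cc2cc1C(c1ccccc1)n1cc(-c2ccc(OC(F)(F)F)cc2)nn1`: -2.24%

In an ADME assay on HeLa cells (Homo sapiens) for cytotoxicity, read by sulforhodamine B assay, with a stated time of 48 h, tested at 10 uM (a lower number here means less inhibition, a higher number more inhibition at the concentration tested (going by the name of the read-out)), compound 2 stands highest of these three numbers, with compound 3 within the scatter of it and compound 1 beyond it. Compound 4, `COc1nc2ccc(Br)cc2cc1C(c1ccccc1)n1cc(CO)nn1`, has not yet been measured. It differs from compound 2 in one place: hydroxymethyl in place of 4-bromophenyl on an aromatic carbon. Among the compounds with values here, two steps bear on this. Replacing cyclopropyl with 4-bromophenyl gave a number 12.8 percentage points higher from compound 1 to compound 2 (beyond the scatter), while swapping one group on the phenyl gave a number 9.2 percentage points lower from compound 2 to compound 3 (within the scatter). Taking the 4-bromophenyl away altogether is therefore expected to move the number modestly downward, toward the level of compound 1, as an estimated step of a number 6.9 percentage points lower from compound 2 to compound 4 (within the scatter). For compound 4 the estimate is 0%, with a range from -12% to 10%.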

Compound 4, a percentage reported as inhibition, at one concentration (the size of the read-out at that concentration, not a potency): 0.25%
The estimate for compound 4 lay 0.3 percentage points below the measured number; the range from low to high includes it.
By their numbers in this assay, from the lowest: compounds 1, 3, 4 and 2 (each within the scatter of the next, the first and the last beyond it).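

In this assay hydroxymethyl, a small group with no ring, can replace each of the other three groups on this aromatic carbon without a step beyond the scatter: 4-bromophenyl (a number 6.7 percentage points lower from compound 2 to compound 4 (within the scatter)), 4-(trifluoromethoxy)phenyl (a number 2.5 percentage points higher from compound 3 to compound 4 (within the scatter)) and cyclopropyl (a number 6.1 percentage points higher from compound 1 to compound 4 (within the scatter)). Adding a hydrogen-bond donor and acceptor here, while losing the six-membered aromatic ring, therefore leaves the number within the scatter of all three earlier compounds. As far as these compounds go, whether an amine, a carboxylic acid or a longer chain at this position would move the number beyond the scatter remains open. No measurement shown accounts for these numbers.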